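Same Nitrogen Change, Longer Chain: What to Expect

This account rests on a few compounds, and the source may have more. Where it says the series, first, only, none or still open, it means among the compounds named here.

Compound 1, `C/C=C/C=C/C(=O)N[C@H](C(=O)NCCCCCCCCCCCC)[C@@H](C)O`: 171000 nM
Compound 2, `CCCCCCCCCCCCNC(=O)[C@@H](NS(=O)(=O)c1ccc(C)cc1)[C@@H](C)O`: 25200 nM
Compound 3, `C/C=C/C=C/C(=O)N[C@H](C(=O)NCCCCCCCCCCCCCCCCCC)[C@@H](C)O`: 187000 nM

The three measured compounds were tested in a functional assay on A-431 cells (Homo sapiens) for cytotoxicity, read by MTT assay, with a stated time of 48 h; a higher number here means a weaker inhibitor, a lower number a stronger inhibitor. Compound 2 differs from compound 1 by a single change, ((4-methylphenyl)sulfonyl in place of (penta-1,3-dien-1-yl)carbonyl on an amine nitrogen), and that change gave a 6.8-fold lower number from compound 1 to compound 2 (0.83 log units; beyond the scatter). Compound 3 differs from compound 1 at the far end of the chain, (hexyl in place of hydrogen on a saturated chain carbon, ten or more bonds along the chain from an amide-type nitrogen), which is how the two cores of this comparison differ; the result was a 1.1-fold higher number from compound 1 to compound 3 (0.04 log units; within the scatter), so compound 1 and compound 3 sit in the same region of this assay.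

Compound 4, `CCCCCCCCCCCCCCCCCCNC(=O)[C@@H](NS(=O)(=O)c1ccc(C)cc1)[C@@H](C)O`, has not yet been measured. It differs from compound 3 by (4-methylphenyl)sulfonyl in place of (penta-1,3-dien-1-yl)carbonyl on an amine nitrogen. The place of this change is described in the same words for both pairs, so it is the same change that was made from compound 1 to compound 2, and among the compounds shown it occurs twice in all.

For compound 4 in this assay the expected step is a 6.7-fold lower number from compound 3 to compound 4 (0.82 log units; beyond the scatter), set beside the earlier 6.8-fold lower number from compound 1 to compound 2 (0.83 log units; beyond the scatter). Among the compounds with values here, this expectation rests on compound 3 having given 187000 nM and on the earlier step being the only measured example of the change. Compound 4 is therefore estimated at 28000 nM. Within the data shown here, the expected range for compound 4 runs from 10000 nM to 80000 nM, wide because only one earlier step, a 6.8-fold lower number from compound 1 to compound 2 (0.83 log units; beyond the scatter), supports it.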

Compound 4, half-maximal inhibitory concentration: 34000 nM
Compound 4: middle estimate off by 1.2-fold (0.08 log units), on the low side; low and high end bracket the measured number.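

In this assay, the change from (penta-1,3-dien-1-yl)carbonyl to (4-methylphenyl)sulfonyl on the amine nitrogen gave a 5.5-fold lower number from compound 3 to compound 4 (0.74 log units; beyond the scatter), so the step seen on the core of compound 1 carried over to the core of compound 3 with its size preserved: the same change on two cores in this assay, a 6.8-fold lower number (0.83 log units; beyond the scatter) from compound 1 to compound 2 and a 5.5-fold lower number (0.74 log units; beyond the scatter) from compound 3 to compound 4, 1.2-fold (0.09 log units) apart, within the scatter of two such steps The longer chain, hexyl in place of hydrogen at the far end, gave a 1.3-fold higher number from compound 2 to compound 4 (0.13 log units; within the scatter), which leaves the two sulfonyl compounds in the same region of this assay, as it did the two dienyl compounds: the same change on two cores in this assay, a 1.1-fold higher number (0.04 log units; within the scatter) from compound 1 to compound 3 and a 1.3-fold higher number (0.13 log units; within the scatter) from compound 2 to compound 4, 1.2-fold (0.09 log units) apart, within the scatter of two such steps This agreement rests on two pairs whose cores differ only in chain length, so it shows that the step carries across that one difference, but not that it would hold on a core altered elsewhere, and it does not show which part of the (4-methylphenyl)sulfonyl group accounts for the step.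

From the compounds shown here alone, it remains open whether a phenylsulfonyl group without the methyl, or a benzoyl group, on the same nitrogen would give a step of similar size. It is also open whether a much shorter chain would stay in the same region of this assay as the two chain lengths shown here.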